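The compounds below may be only part of what the source reports. "The series", "measured", "known", "first", "only" and "open" are said of these compounds alone.

Working notes on the series in a toxicity assay on L02 cells (Homo sapiens) for cytotoxicity, read by MTT assay, with a stated time of 72 h; a higher number here means a weaker inhibitor, a lower number a stronger inhibitor. Compound 1 `CN(C)CCCCCn1c2c(c3ccccc31)C(=O)c1c[n+]([O-])c3ccccc3c1C2=O` gives 240 nM, compound 2 `O=C1c2c[n+]([O-])c3ccccc3c2C(=O)c2c1c1ccccc1n2Cc1cn([C@@H]2C[C@H](O)[C@@H](CO)O2)nn1` gives 630 nM and compound 3 `O=C1c2c[n+]([O-])c3ccccc3c2C(=O)c2c1c1ccccc1n2Cc1cn(C[C@H](O)CO)nn1` gives 1130 nM as the highest of the three numbers, although its gap to compound 2 stays within the scatter. Compound 4 `CN1CCN(CCCCn2c3c(c4ccccc42)C(=O)c2c[n+]([O-])c4ccccc4c2C3=O)CC1` has 3-(4-methylpiperazin-1-yl)propyl in place of 1-(2,3-dihydroxypropyl)-1H-1,2,3-triazol-4-yl on a saturated chain carbon bound to an aromatic nitrogen. Among the measured compounds shown here, the closest precedent is a 4.7-fold higher number from compound 1 to compound 3 (0.67 log units; beyond the scatter), where the same triazolyl group enters in place of 4-(dimethylamino)butyl. For the measured compounds named here, the change to compound 4 runs the other way, though with a different chain, and no measured step covers that chain. The other measured step, a 1.8-fold higher number from compound 2 to compound 3 (0.25 log units; within the scatter), alters only the group on the triazole's aromatic nitrogen and gives little guidance. A modest move towards a lower number, similar in size to the first step, is therefore expected in this assay. The expected move is a 3.8-fold lower number from compound 3 to compound 4 (0.58 log units; beyond the scatter). The estimate for compound 4 is 300 nM, with an expected range of 120 nM to 750 nM.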

Compound 4, half-maximal inhibitory concentration: 80 nM
Beside the measured number, compound 4's estimate is 3.8-fold (0.57 log units) above it; measured number outside the range, below it.
By their numbers in this assay, from the lowest: compound 4; then compound 1; then compounds 2 and 3 (each within the scatter of the next).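

In this assay, among the compounds shown here, replacing the triazolyl group with 3-(4-methylpiperazin-1-yl)propyl on the saturated chain carbon bound to an aromatic nitrogen gives a 14-fold lower number from compound 3 to compound 4 (1.15 log units; beyond the scatter) and is the largest step so far. The amine-bearing side chains also differ from each other, since 4-methylpiperazin-1-yl in place of (dimethylamino)methyl gives a 3.0-fold lower number from compound 1 to compound 4 (0.48 log units; beyond the scatter) and the change lies beyond the scatter, so this position responds to the amine-bearing end of the chain and not only to removal of the triazole. No measurement in hand accounts for either step.

Going by these compounds, whether the second ring nitrogen of the piperazine is needed remains open, and a piperidin-1-yl or morpholin-4-yl group on the chain of compound 4 would address this. The step from compound 1 also changes the chain as a whole, so the contribution of the ring is not separated from that of chain length.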